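The source may hold more compounds than are shown below. What is called first, only, known or untested is meant among the compounds shown, and "the series" means these compounds.

In a functional assay on HeLa cells (Homo sapiens) for antiproliferative activity, read by MTT assay, with a stated time of 72 h (a higher number here means a weaker inhibitor, a lower number a stronger inhibitor), compound 1 (`CCN(CC)C(=S)SCC1=CC(=O)OC1`) gives 21000 nM, and compound 2 (`CN1CCN(C(=S)SCC2=CCOC2=O)CC1`) gives 770 nM. Compound 3 (`CCNC(=S)SCC1=CCOC1=O`) has no number in this test. It is reported only as "not active" (no number reported), so its place can be told in words but not as a figure.

The compound still to be measured is compound 4 (`CN(C)C(=S)SCC1=CCOC1=O`). The structural change is dimethylamino in place of ethylamino on a thiocarbonyl carbon.

Going by the values given here, no measured pair of compounds isolates this change, so the data give no direct size for the step in this assay. Among the compounds with values here, the only guide is a comparison among three compounds. The nitrogen on the thiocarbonyl carbon carries no hydrogen in compound 4, and the same is true of compound 1 at 21000 nM and compound 2 at 770 nM, whereas in compound 3 it does carry one. On that weak basis, the expected step is towards stronger inhibition, from no reported activity to a measurable value of uncertain size. A result with no number remains possible. The estimated value for compound 4 is 4000 nM, with an expected range of 600 nM to 25000 nM.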

Compound 4, half-maximal inhibitory concentration: 114000 nM
Beside the measured number, compound 4's estimate is 29-fold (1.45 log units) below it, outside the stated range (above it).
By their numbers in this assay, from the lowest: compound 2; then compound 1; then compound 4.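

In this assay, going by these compounds alone, compound 4 gives 114000 nM while compound 3 is reported only as "not active", so no step between compound 3 and compound 4 can be read. The compounds shown leave open how dimethylamino in place of ethylamino changes activity on its own. Nothing in the data given bears on the reason for this result.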